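A Bromo Group Added to Compound 1

The compounds below may be only part of what the source reports. "The series", "measured", "known", "first", "only" and "open" are said of these compounds alone.

In a functional assay on HT-29 cells (Homo sapiens) (on this read-out lower numbers stand for stronger inhibition of growth and higher numbers for weaker inhibition of growth), compound 1 `O=S(=O)(/C=C/c1ccc(Cl)cc1Cl)Cc1ccc(Nc2ncnc3ccccc23)cc1` gives 24000 nM, the middle of three measured numbers. Compound 2 `O=S(=O)(/C=C/c1ccc(C(F)(F)F)cc1F)Cc1ccc(Nc2ncnc3ccccc23)cc1` gives 100000 nM, and compound 3 `O=S(=O)(/C=C/c1ccc(O)cc1)Cc1ccc(Nc2ncnc3ccccc23)cc1` gives 2000 nM. These three compounds differ only in the group on the double-bonded chain carbon. Replacing 2,4-dichlorophenyl with 2-fluoro-4-(trifluoromethyl)phenyl gives a 4.2-fold higher number from compound 1 to compound 2 (0.62 log units; beyond the scatter), while replacing it with 4-hydroxyphenyl gives a 12-fold lower number from compound 1 to compound 3 (1.08 log units; beyond the scatter). Between those two replacements lies a 50-fold lower number from compound 2 to compound 3 (1.70 log units; beyond the scatter).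

Compound 4 `O=S(=O)(/C=C/c1ccc(Cl)cc1Cl)Cc1ccc(Nc2ncnc3ccc(Br)cc23)cc1` keeps the 2,4-dichlorophenyl group and changes the shared core instead: bromo in place of hydrogen on an aromatic carbon. Here, bromo replaces hydrogen on an aromatic carbon of a six-membered aromatic ring of carbon only, part of a fused or bridged system of two rings. Among the compounds with values here, none of the measured steps involves this place, so they offer no guide to the size or direction of this change. With no such evidence, no change beyond the scatter is expected, and the estimated step is a 1.2-fold lower number from compound 1 to compound 4 (0.08 log units; within the scatter). For compound 4, the expected value is 20000 nM, within an estimated range of 6000 nM to 70000 nM.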

Compound 4, concentration for 50% growth inhibition: 28000 nM
For compound 4 the middle estimate is 1.4-fold (0.15 log units) below the measured one; low and high end bracket the measured number.
By their numbers in this assay, from the lowest: compound 3; then compounds 1 and 4 (each within the scatter of the next); then compound 2.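

Placing bromo on this aromatic carbon of the shared core gives a 1.2-fold higher number from compound 1 to compound 4 (0.07 log units; within the scatter) in this assay, so compound 1 and compound 4 cannot be told apart on this read-out. Within the data shown here, the earlier steps all changed the group on the double-bonded chain carbon and all lay beyond the scatter, whereas this step is the first to touch the core, and with the 2,4-dichlorophenyl group in place, one added bromine makes no measurable difference here. Nothing available here explains this result.

From the compounds shown here alone, it remains open whether bromo would do the same alongside the 4-hydroxyphenyl group of compound 3, where the number is far lower. Also unsettled is how a different group at this place, such as an amine or a carboxylic acid, would compare.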